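This account rests on a few compounds, and the source may have more. Where it says the series, first, only, none or still open, it means among the compounds named here.

Among the measured compounds shown here, compound 2 `CS(=O)(=O)N1CC(CCl)c2ccc(N)cc21` gives 33000 nM in a functional assay on EMT6 cells (Mus musculus) for cytotoxicity, with a stated time of 4 h (on this read-out lower numbers stand for stronger inhibition and higher numbers for weaker inhibition), the higher of the two numbers measured so far, while compound 1 `CS(=O)(=O)N1CC(CCl)c2ccc(O)cc21` gives 7700 nM. For the measured compounds named here, the only measured step, a 4.3-fold higher number from compound 1 to compound 2 (0.63 log units; beyond the scatter), replaces a hydroxy with an amino on the aromatic ring. Compound 3 `CNc1ccc2c(c1)N(S(C)(=O)=O)CC2CCl` differs from compound 2 by methyl in place of hydrogen on a nitrogen on an aromatic ring. Going by the values given here, no measured step adds a methyl on that nitrogen, so the single known step bears on the question only indirectly, in showing that a change at this position moves this assay by a modest amount rather than a large one. A step of similar or smaller size is therefore expected, with the direction uncertain and a slight lean toward a lower number, so that the expected step is a 1.7-fold lower number from compound 2 to compound 3 (0.22 log units; within the scatter). Compound 3 is estimated at 20000 nM, with a range from 6000 nM to 70000 nM.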

Compound 3, half-maximal inhibitory concentration: 13000 nM
The estimate for compound 3 lay 1.5-fold (0.19 log units) above the measured number, within the range that was stated.
By their numbers in this assay, from the lowest: compounds 1 and 3 (each within the scatter of the next); then compound 2.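

In this assay the result shows that this nitrogen tolerates substitution, and that a single methyl there gives a 2.5-fold lower number from compound 2 to compound 3 (0.40 log units; beyond the scatter) rather than a number that climbs further. The earlier compounds shown here held only a hydrogen on this nitrogen, so the step from hydroxy to amino (a 4.3-fold higher number from compound 1 to compound 2 (0.63 log units; beyond the scatter)) could not show this; the methylamino compound now stands within the scatter of the hydroxy compound (a 1.7-fold higher number from compound 1 to compound 3 (0.23 log units; within the scatter)), and the higher number of compound 2 does not carry over to compound 3. No evidence is available that accounts for this step.

From the compounds shown here alone, whether the trend continues with a second methyl on the same nitrogen (dimethylamino), a longer chain such as ethyl, or an acetyl there remains open. Going by these compounds, it is equally open how methoxy in place of hydroxy would compare with methylamino.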